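The source may hold more compounds than are shown below. What is called first, only, known or untested is meant among the compounds shown, and "the series" means these compounds.

For the measured compounds named here, compound 2 `COc1ccc(CCCCNC(C)=O)cc1` shows the highest of the two numbers recorded so far in an assay for binding affinity to melatonin receptor (Gallus gallus) (on this read-out lower numbers stand for stronger inhibition and higher numbers for weaker inhibition), where compound 2 gives 7300 nM; the only neighbour, compound 1 `CCC(=O)NCCCc1ccc(OC)cc1`, gives 2900 nM in this assay. Compound 3 `CCC(=O)NCCCCc1ccc(OC)cc1` differs from compound 2 by methyl in place of hydrogen on a saturated chain carbon bound to a carbonyl carbon. Going by the values given here, only one measured step bears on this: a 2.5-fold higher number from compound 1 to compound 2 (0.40 log units; beyond the scatter), a step that also lengthens the chain, so the two parts cannot be separated. Since the acyl part of that step is reversed here, a modest drop is expected, a 2.1-fold lower number from compound 2 to compound 3 (0.32 log units; beyond the scatter). Compound 3 is therefore estimated at 3500 nM, within 1200 nM to 10000 nM.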

Compound 3, inhibition constant: 1400 nM
Beside the measured number, compound 3's estimate is 2.5-fold (0.40 log units) above it; measured number inside the range.
By their numbers in this assay, from the lowest: compound 3; then compound 1; then compound 2.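

In this assay the change from acetamido to propanoylamino gives a 5.2-fold lower number from compound 2 to compound 3 (0.72 log units; beyond the scatter) with the chain held fixed, which separates the acyl part from the chain lengthening mixed into the earlier step. One added methyl on the saturated chain carbon bound to a carbonyl carbon is therefore enough, on its own, to shift the number beyond the usual scatter towards stronger inhibition. No available evidence explains this shift. On these data alone, whether a butanoyl group, with its longer chain, would lower the number further stays open. Also open, as far as these compounds go, is whether the methyl would matter as much on the shorter chain of compound 1.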